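The compounds below may be only part of what the source reports. "The series", "measured", "known", "first", "only" and "open" are said of these compounds alone.

Compound 1 `Cc1nc(C(=O)Nc2ccc(Cl)c(-c3nnc4c(Cl)cccn34)c2)cs1` is one of three measured compounds. In a functional assay on A549 cells (Homo sapiens) for antiproliferative activity, read by MTT assay, with a stated time of 72 h (on this read-out lower numbers stand for stronger inhibition and higher numbers for weaker inhibition), compound 1 gives only a limit, > 100000 nM. Compound 2 `Cc1cc(Cl)ccc1C(=O)Nc1ccc(Cl)c(-c2nnc3c(Cl)cccn23)c1` in this assay likewise gives only a limit, > 100000 nM. Compound 3 `O=C(Nc1ccc(Cl)c(-c2nnc3c(Cl)cccn23)c1)c1cccnc1Cl` in this assay gives 35800 nM.

For the measured compounds named here, compound 3 therefore stands as the only compound of the three with a number rather than a limit, the other two sitting at the limit of > 100000 nM in this assay, at which 2 of the 3 values shown sit. The shared core is kept throughout and only the aryl on the carbonyl carbon changes. Compound 4 `CS(=O)(=O)c1cccc(C(=O)Nc2ccc(Cl)c(-c3nnc4c(Cl)cccn34)c2)c1` continues this series: 3-(methylsulfonyl)phenyl in place of 2-chloropyridin-3-yl on a carbonyl carbon.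

Going by the values given here, two measured steps bear on this change, both arriving at the 2-chloropyridin-3-yl of compound 3: an at least 2.7-fold lower number from compound 1 to compound 3 (0.44 log units; beyond the scatter) and an at least 2.7-fold lower number from compound 2 to compound 3 (0.44 log units; beyond the scatter). Both show that leaving the pyridine for another aryl on the carbonyl carbon has given a higher number or a limit. Compound 4 leaves the pyridine as well, so a rise in the number is expected, a 2.0-fold higher number from compound 3 to compound 4 (0.29 log units; within the scatter), with a real chance that this assay again reports only a limit. Compound 4 is estimated at 70000 nM, within 20000 nM to 250000 nM.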

Compound 4, half-maximal inhibitory concentration: > 100000 nM
Compound 4: a limit, no number; the forecaster's own chance of this, stated with the estimate: 45%; middle value at least 1.4-fold (0.15 log units) away from the limit.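

In this assay, replacing the 2-chloropyridin-3-yl on the carbonyl carbon with 3-(methylsulfonyl)phenyl gives an at least 2.7-fold higher number from compound 3 to compound 4 (0.44 log units; beyond the scatter), so a third aryl group, this one with a ring of carbon only, has lost the measurable number that compound 3 gives. Among the four compounds shown, only the 2-chloropyridin-3-yl of compound 3 gives a number rather than a limit, and the limit is now shared more widely: the limit of > 100000 nM in this assay, at which 3 of the 4 values shown sit. The steps linking compound 1, compound 2 and compound 4 cannot be read, as all three values are limits.

Going by these compounds, how far these three lie past the limit stays unknown. On these data alone, it is also open whether the ring nitrogen or the chlorine of compound 3 matters more, a question that a plain pyridin-3-yl or a 2-chlorophenyl on the carbonyl carbon would address.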